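Iodo for chloro on the aromatic carbon of a urea

The source may hold more compounds than are shown below. What is called first, only, known or untested is meant among the compounds shown, and "the series" means these compounds.

Of the compounds shown here, two have been measured so far. Compound 1 `CCOC(=O)c1cccc(NC(=O)N[C@@H](C)c2ccccc2)c1` gives 100% in an ADME assay on the whole organism with Oryza sativa as the target, tested at 0.1 uM (on this read-out lower numbers stand for a stronger effect and higher numbers for a weaker effect at the one concentration tested), and compound 2 `C[C@H](NC(=O)Nc1cccc(Cl)c1)c1ccccc1` gives 103% in this assay. The only step recorded between them, a number 3 percentage points higher from compound 1 to compound 2 (within the scatter), was chloro in place of ethoxycarbonyl on an aromatic carbon, so compound 2 stands within the scatter of compound 1, the sole other number shown.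

Compound 3 `C[C@H](NC(=O)Nc1cccc(I)c1)c1ccccc1` differs from compound 2 by iodo in place of chloro on an aromatic carbon. Among the compounds with values here, no measured step bears directly on iodo in place of chloro; the one step available, from compound 1 to compound 2, stayed within the scatter, and both measured numbers sit near no effect. Compound 3 is therefore expected to show a step of a number 3 percentage points lower from compound 2 to compound 3 (within the scatter), none beyond the scatter. Compound 3 is estimated at 100%, with a range from 88% to 110%.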

Compound 3, a percentage reported as activity, at one concentration (the size of the read-out at that concentration, not a potency): 98%
Compound 3: the middle estimate sits 2 percentage points above what was measured, and the stated range covers the measured number.
By their numbers in this assay, from the lowest: compounds 3, 1 and 2 (each within the scatter of the next).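

In this assay, the change of one halogen for another on this aromatic carbon, meta to a large group, gives a number 5 percentage points lower from compound 2 to compound 3 (within the scatter). Iodo in place of ethoxycarbonyl at the same place gives a number 2 percentage points lower from compound 1 to compound 3 (within the scatter), so ethoxycarbonyl, chloro and iodo now form a set of three groups at this position whose numbers cannot be told apart. The earlier pair had shown this for only two groups, and iodo, the new group, extends it without separating any compound from the others. Nothing measured here explains this lack of separation.

As far as these compounds go, whether an amine or a carboxylic acid on this aromatic carbon would give a step beyond the scatter remains open. Equally open, from the compounds shown here alone, is whether a change to the urea, or a longer chain in place of its methyl branch, would move the number.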